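Changing the Ring on Sulfur: An Expected Cytotoxicity Value

The compounds below may be only part of what the source reports. "The series", "measured", "known", "first", "only" and "open" are said of these compounds alone.

Measured compounds:
Compound 2 `Cc1ccc(-c2cs/c(=N/NC(=O)CSc3nncn3C)n2-c2ccccc2)cc1` in a functional assay on C6 cells (Rattus norvegicus) for cytotoxicity, read by MTT assay, with a stated time of 24 h (a higher number here means a weaker inhibitor, a lower number a stronger inhibitor), gives 56 ug/mL.
Compound 3 `Cn1cnnc1SCC(=O)N/N=c1/scc(-c2ccccc2)n1-c1ccccc1` in this assay gives 68.3 ug/mL.
Compound 1 `Cn1cnnc1SCC(=O)N/N=c1/scc(-c2ccc([N+](=O)[O-])cc2)n1-c1ccccc1` in this assay gives "not determined" (no result reported), that is, no reported result.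

Among the measured compounds shown here, compound 2 shows the lowest of the two numbers, but its only neighbour, compound 3, lies within the scatter: a 1.2-fold higher number from compound 2 to compound 3 (0.09 log units; within the scatter). Compound 4 `Cc1ccc(-c2cs/c(=N/NC(=O)CSc3ncccn3)n2-c2ccccc2)cc1` differs from compound 2 by pyrimidin-2-yl in place of 4-methyl-4H-1,2,4-triazol-3-yl on a sulfur. For the measured compounds named here, no measured step touches this part of the molecule, so the one known step, from compound 2 to compound 3, does not bear on it; it only shows that a small change elsewhere left the number where it was. With no guide, compound 4 is expected to stay close to compound 2, with a 1.1-fold higher number from compound 2 to compound 4 (0.03 log units; within the scatter), giving an estimate of 60 ug/mL, within the range 25 ug/mL to 140 ug/mL.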

Compound 4, half-maximal inhibitory concentration: 85 ug/mL
Beside the measured number, compound 4's estimate is 1.4-fold (0.15 log units) below it; low and high end bracket the measured number.
By their numbers in this assay, from the lowest: compounds 2, 3 and 4 (each within the scatter of the next).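

In this assay, replacing 4-methyl-4H-1,2,4-triazol-3-yl with pyrimidin-2-yl on the sulfur gives a 1.5-fold higher number from compound 2 to compound 4 (0.18 log units; within the scatter). This first look at this position shows that a five-membered aromatic ring with 3 hetero atoms and a six-membered aromatic ring with 2 hetero atoms can both sit here with no clear difference in the number. Nothing shown offers an explanation for this result. Still open, going by these compounds, is whether an amine or a carboxylic acid on this sulfur would move the number beyond the scatter.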